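The source may hold more compounds than are shown below. What is called first, only, known or untested is meant among the compounds shown, and "the series" means these compounds.

Values in an ADME assay on cells (spleen, Mus musculus, strain C57BL/6) for inhibition, read by flow cytometry and propidium iodide staining, with a stated time of 24 h, at 37 degrees C (on this read-out lower numbers stand for an effect already at smaller amounts and higher numbers for an effect only at larger amounts of compound), so far:
Compound 1 `O=C(Cn1cc(CCCCO)nn1)NCc1ccccc1` gives 1700 uM
Compound 2 `Cc1ccc(-c2cn(CC(=O)NCc3ccccc3)nn2)cc1` gives "non-toxic" (no number reported)
Compound 3 `Cc1ccccc1-c1cn(CC(=O)NCc2ccccc2)nn1` gives 940 uM

For the measured compounds named here, compound 3 and compound 1 hold the only two numbers in this assay and lie within the scatter of each other, while compound 2 has no number. Compound 4 `O=C(Cn1cc(-c2cccc(F)c2)nn1)NCc1ccccc1` differs from compound 3 as follows: 3-fluorophenyl in place of 2-methylphenyl on an aromatic carbon. Going by the values given here, the one measured step on that carbon is a 1.8-fold lower number from compound 1 to compound 3 (0.26 log units; within the scatter) (4-hydroxybutyl to 2-methylphenyl). No change beyond the scatter is therefore expected, in either direction. The expected step is a 1.1-fold higher number from compound 3 to compound 4 (0.03 log units; within the scatter) (an estimate). For compound 4 the estimated value is 1000 uM (expected range 400 uM to 2500 uM).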

Compound 4, concentration for half-maximal effect: "non-toxic" (no number reported)
The entry for compound 4 holds no number; there is nothing to compare the estimate with.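

For the compounds shown here, with compound 4 at "non-toxic" (no number reported) no step from compound 3 can be read, and no evidence bears on this result. The compounds shown leave open whether 3-fluorophenyl in place of 2-methylphenyl changes the read-out at all.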